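Thiophene for pyridine on the cyclopropane of compound 3

The source may hold more compounds than are shown below. What is called first, only, known or untested is meant among the compounds shown, and "the series" means these compounds.

Working notes on the cyclopropanecarboxamide series. Compound 1 `CC[C@H](C)[C@H](N)CN(C(=O)[C@@H]1C[C@H]1c1ccccc1)c1ccc(-c2ccccc2)cc1` is the phenyl parent; in a functional assay for agonist activity at G protein-coupled receptor 88 (Homo sapiens), read by HTRF and cAMP accumulation (on this read-out lower numbers stand for an effect already at smaller amounts and higher numbers for an effect only at larger amounts of compound), compound 1 gives 230 nM; 800 nM (2 entries), and the spread of these repeats the several entries of compound 1 in this assay, 230 nM; 800 nM (2 entries) shows how far two measurements of one compound can lie apart here. Compound 2 `CC[C@H](C)[C@H](N)CN(C(=O)[C@@H]1C[C@H]1c1cccc(C#N)c1)c1ccc(-c2ccccc2)cc1` carries a 3-cyanophenyl ring and gives 1600 nM in this assay. Compound 3 `CC[C@H](C)[C@H](N)CN(C(=O)[C@@H]1C[C@H]1c1cccnc1)c1ccc(-c2ccccc2)cc1` carries pyridin-3-yl at the same place and gives 1500 nM in this assay; the step of a 1.1-fold lower number from compound 2 to compound 3 (0.03 log units; within the scatter) is within the scatter, so compound 2 and compound 3 cannot be told apart on these numbers, and compound 1 has two entries without a single number.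

Compound 4 `CC[C@H](C)[C@H](N)CN(C(=O)[C@@H]1C[C@H]1c1ccsc1)c1ccc(-c2ccccc2)cc1` differs from compound 3 by thiophen-3-yl in place of pyridin-3-yl on a saturated ring carbon. Among the compounds with values here, the only measured step at this position, a 1.1-fold lower number from compound 2 to compound 3 (0.03 log units; within the scatter), exchanged one aromatic ring for another without a change beyond the scatter. A change in this assay beyond the scatter is therefore not expected, in either direction. Compound 4 is estimated at 1200 nM, with a range from 400 nM to 3600 nM. This estimate corresponds to an expected step of a 1.3-fold lower number from compound 3 to compound 4 (0.10 log units; within the scatter).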

Compound 4, half-maximal effective concentration: 450 nM
Compound 4: the middle estimate sits 2.7-fold (0.43 log units) above what was measured; the measured number falls inside the stated range.
By their numbers in this assay, from the lowest: compound 4; then compounds 3 and 2 (each within the scatter of the next).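

Within the data shown here, at this position the aromatic ring is not freely exchangeable: in this assay, thiophen-3-yl in place of pyridin-3-yl gives a 3.3-fold lower number from compound 3 to compound 4 (0.52 log units; beyond the scatter), the first step here beyond the scatter. Thiophen-3-yl in place of 3-cyanophenyl gives a 3.6-fold lower number from compound 2 to compound 4 (0.55 log units; beyond the scatter), so the two six-membered rings that could not be told apart both separate from the five-membered one. The change replaces both ring size and hetero atom, and these numbers do not divide the step between the two.

Steps involving compound 1 cannot be read, as it has no single number: the several entries of compound 1 in this assay, 230 nM; 800 nM (2 entries). Open, from the compounds shown here alone, is whether thiophen-2-yl or furan-3-yl would read like thiophen-3-yl, and how a carboxylic acid or an aminomethyl group on the thiophen-3-yl ring would read.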